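Removing the Aryl Group from a Non-Cytotoxic Series

The source may hold more compounds than are shown below. What is called first, only, known or untested is meant among the compounds shown, and "the series" means these compounds.

Compound 1 `Cc1cc(/C=C2\S/C(=N\c3ccccc3)N(C3CCCCC3)C2=O)c(C)n1-c1ccc(C(F)(F)F)cc1` was tested in an ADME assay on L6 cells (Rattus norvegicus) for cytotoxicity, read by microscopy and resazurin assay, with a stated time of 72 h; on this read-out lower numbers stand for an effect already at smaller amounts and higher numbers for an effect only at larger amounts of compound. In this assay compound 1 reaches only the limit > 170000 nM, so no number is known for it. Compound 2 `Cc1cc(/C=C2\S/C(=N\c3ccccc3)N(C3CCCCC3)C2=O)c(C)n1-c1cccc(C(F)(F)F)c1` likewise gives only the limit > 170000 nM. Compound 3 `O=C1/C(=C/c2ccn(-c3ccccc3C(F)(F)F)c2)S/C(=N\c2ccccc2)N1C1CCCCC1` gives only the limit > 180000 nM. The step that the two limits leave unreadable from compound 1 to compound 2 therefore cannot be read. Compound 4 `Cc1cc(/C=C2\S/C(=N\c3ccccc3)N(C3CCCCC3)C2=O)c(C)[nH]1` differs from compound 1 by hydrogen in place of 4-(trifluoromethyl)phenyl on an aromatic nitrogen. Within the data shown here, none of the measured steps has a readable size, and all three values rest at limits, as the limit of > 170000 nM in this assay, at which 2 of the 3 values shown sit, and the limit of > 180000 nM in this assay, at which 1 of the 3 values shown sits, show. The step of a number no higher from compound 1 to compound 4 (the limit leaves the size open) is therefore expected to be of no clear size and to leave the read-out at the limit. Compound 4 is estimated at about 170000 nM, between 60000 nM and 400000 nM.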

Compound 4, half-maximal effective concentration: 23000 nM
For compound 4 the middle estimate is 7.4-fold (0.87 log units) above the measured one; the whole stated range lies above it.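

Replacing the aryl group with hydrogen on this aromatic nitrogen gives an at least 7.3-fold lower number from compound 1 to compound 4 (0.86 log units; beyond the scatter) and an at least 7.3-fold lower number from compound 2 to compound 4 (0.86 log units; beyond the scatter). Among these compounds, this is the first change to move the read-out off a limit, so the cells now respond at a measurable amount of compound. Compound 1 and compound 2 each remain at a limit, so both steps give only a minimum size and the step between those two compounds cannot be read: the limit of > 170000 nM in this assay, at which 2 of the 4 values shown sit.

From the compounds shown here alone, the true size of the drop stays open. So does whether a plain phenyl group, a methyl group or a longer chain such as butyl on this nitrogen would behave like hydrogen or like the trifluoromethyl-bearing aryl groups.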